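This account rests on a few compounds, and the source may have more. Where it says the series, first, only, none or still open, it means among the compounds named here.

Of the compounds shown here, three sharing one core have been tested in a functional assay on DU-145 cells (Homo sapiens) for antiproliferative activity, read by sulforhodamine B assay, with a stated time of 3 days; on this read-out lower numbers stand for stronger inhibition of growth and higher numbers for weaker inhibition of growth. Compound 1 `Cn1ccnc1NC(=O)c1cccc(Nc2ncc(F)c(Nc3ccc(F)cc3)n2)c1` gives 15100 nM in this assay, and compound 2 `O=C(Nc1ccccn1)c1cccc(Nc2ncc(F)c(Nc3ccc(F)cc3)n2)c1` gives 15100 nM; the step of no change at the digits printed from compound 1 to compound 2 (within the scatter) shows that swapping one heteroaryl for another on the amide-type nitrogen left the read-out unchanged. Compound 3 `O=C(Nc1cccc(Nc2ncc(F)c(Nc3ccc(F)cc3)n2)c1)c1ccncc1` gives 4330 nM, the lowest of the three numbers, and its separation from both others lies beyond the scatter: a 3.5-fold lower number from compound 1 to compound 3 (0.54 log units; beyond the scatter) and a 3.5-fold lower number from compound 2 to compound 3 (0.54 log units; beyond the scatter) describe the same reversed amide bearing a pyridin-4-yl carbonyl.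

Compound 4 `COCC(=O)Nc1cccc(Nc2ncc(F)c(Nc3ccc(F)cc3)n2)c1` keeps that reversed amide but alters the group on the carbonyl carbon: methoxymethyl in place of pyridin-4-yl on a carbonyl carbon. Among the measured compounds shown here, no measured step replaces an aromatic ring on the carbonyl carbon with a chain, so nothing here speaks directly to this change. For the measured compounds named here, the only guidance is that the two rearrangements leading to compound 3 were each of modest size, and that the heteroaryl swap from compound 1 to compound 2 produced nothing beyond the scatter. The step of a 1.6-fold higher number from compound 3 to compound 4 (0.21 log units; within the scatter) is therefore expected to be small, most likely a modest rise in the number. Compound 4 is estimated at 7000 nM, with a range from 2500 nM to 20000 nM.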

Compound 4, concentration for 50% growth inhibition: 4460 nM
The estimate for compound 4 lay 1.6-fold (0.20 log units) above the measured number, and the stated range covers the measured number.
By their numbers in this assay, from the lowest: compounds 3 and 4 (each within the scatter of the next); then compounds 1 and 2 (each within the scatter of the next).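

In this assay, replacing pyridin-4-yl on the carbonyl carbon with methoxymethyl removes the aromatic ring and leaves a smaller group with no ring, yet the result is a 1.0-fold higher number from compound 3 to compound 4 (0.01 log units; within the scatter), so a ring at this place is not required to keep the read-out of compound 3. The separation from the amides of the opposite orientation also persists without the ring, as shown by a 3.4-fold lower number from compound 2 to compound 4 (0.53 log units; beyond the scatter) and by a 3.4-fold lower number from compound 1 to compound 4 (0.53 log units; beyond the scatter), so the lower numbers go with the reversed amide carrying either of these two groups and not with pyridin-4-yl alone. No supporting measurement among the available data accounts for this tolerance at the carbonyl carbon.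

The compounds shown leave open whether the oxygen of methoxymethyl matters, which a plain ethyl or propyl group on the same carbonyl carbon would test, and how far the position tolerates a longer chain such as 2-methoxyethyl. They also leave open whether a dimethylaminomethyl group, a carboxylic acid or a phenyl ring at this place would fall within the scatter of compound 3 and compound 4 or move the number.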